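The source may report more compounds than this note shows. Statements on the series, on what has been measured and on what is new or still open speak of the compounds shown alone.

Measured compounds and their readings:

Compound 1, `COC(=O)[C@H](CO)NC(=O)/C=C/c1ccc(OC)cc1`, gives 103% in an ADME assay on Vero cells (Chlorocebus sabaeus) for cytotoxicity, read by WST assay, tested at 100 ug/mL; on this read-out lower numbers stand for a stronger effect and higher numbers for a weaker effect at the one concentration tested.
Compound 2, `COC(=O)[C@H](CO)NC(=O)/C=C/c1ccc(C)cc1`, gives 101% in this assay.
Compound 3, `COC(=O)c1coc(/C=C/c2ccc(OC)cc2)n1`, gives 96.8% in this assay.

The change from compound 1 to compound 2 is methyl in place of methoxy on an aromatic carbon, and it made the step of a number 2 percentage points lower from compound 1 to compound 2 (within the scatter). Compound 4, `COC(=O)c1coc(/C=C/c2ccc(C)cc2)n1`, has not been measured; it differs from compound 3 by methyl in place of methoxy on an aromatic carbon, the same change on the same kind of position. How the core of compound 3 differs from that of compound 1 is not broken down here. Because the earlier step of a number 2 percentage points lower from compound 1 to compound 2 (within the scatter) stayed within the scatter, the step of a number 1.8 percentage points lower from compound 3 to compound 4 (within the scatter) is expected to be of a similar small size. Compound 4 is therefore estimated to give 95% in this assay, expected to fall between 85% and 105%.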

Compound 4, a percentage reported as activity, at one concentration (the size of the read-out at that concentration, not a potency): 100%
Compound 4: middle estimate off by 5 percentage points, on the low side, within the range that was stated.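

The change of methoxy to methyl on the second core gave a number 3.2 percentage points higher from compound 3 to compound 4 (within the scatter) in this assay. Set beside the earlier step, the change behaves no differently on the two cores: the same change on two cores in this assay, a number 2 percentage points lower (within the scatter) from compound 1 to compound 2 and a number 3.2 percentage points higher (within the scatter) from compound 3 to compound 4, 5.2 percentage points apart, within the scatter of two such steps. This shows that the change stayed within the scatter on both cores at the one concentration tested, but it gives the change no direction and does not show that it would stay as small on any other core.

The compounds shown leave open what other groups on the same aromatic carbon, such as chlorine, a nitrile or an amine, would do. They also leave open whether a carboxylic acid in place of the methyl ester would alter the reading.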